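The source may hold more compounds than are shown below. What is called first, only, known or untested is meant among the compounds shown, and "the series" means these compounds.

Of the compounds shown here, two built on a shared core have been tested in a functional assay on HT-29 cells (Homo sapiens) for cytotoxicity, read by MTT assay, with a stated time of 72 h; a lower number here means a stronger inhibitor, a higher number a weaker inhibitor. Compound 1 `COc1cc2c(Oc3ccc(NC(=O)c4cn(-c5ccccc5OC)cn4)cc3F)ccnc2cc1OCCCN1CCCCC1` gives 100 nM in this assay. Among the measured compounds shown here, compound 2 `COc1cc2c(Oc3ccc(NC(=O)c4cn(-c5ccccc5OC(F)(F)F)cn4)cc3F)ccnc2cc1OCCCN1CCCCC1` gives 250 nM, the higher of the two numbers measured so far. For the measured compounds named here, the single measured step, a 2.5-fold higher number from compound 1 to compound 2 (0.40 log units; beyond the scatter), is the one that separates them. Compound 3 `COc1cc2c(Oc3ccc(NC(=O)c4cn(-c5ccc(Cl)cc5)cn4)cc3F)ccnc2cc1OCCCN1CCCCC1` has not been measured; it differs from compound 2 by 4-chlorophenyl in place of 2-(trifluoromethoxy)phenyl on an aromatic nitrogen. Going by the values given here, the measured step bears on this change only in part: it shows that altering the group on the oxygen shifted the number by a modest amount, but no measured pair shows what removing the whole oxygen-bearing group and introducing a chlorine-bearing phenyl does. With that gap acknowledged, the change is expected to give a 1.7-fold lower number from compound 2 to compound 3 (0.22 log units; within the scatter), with wide uncertainty. Compound 3 is estimated at 150 nM, in a range from 50 nM to 450 nM.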

Compound 3, half-maximal inhibitory concentration: 2780 nM
Compound 3: the middle estimate sits 19-fold (1.27 log units) below what was measured; measured number outside the range, above it.
By their numbers in this assay, from the lowest: compound 1; then compound 2; then compound 3.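

In this assay the aryl group on the aromatic nitrogen matters far more than the first pair suggested. Replacing 2-(trifluoromethoxy)phenyl with 4-chlorophenyl gives an 11-fold higher number from compound 2 to compound 3 (1.05 log units; beyond the scatter) and replacing 2-methoxyphenyl with it gives a 28-fold higher number from compound 1 to compound 3 (1.44 log units; beyond the scatter) while changing only the group on the oxygen gave just a 2.5-fold higher number from compound 1 to compound 2 (0.40 log units; beyond the scatter) so the larger loss comes with replacing the whole aryl group. Nothing available explains why this swap costs so much.

Compound 3 differs from compound 1 and compound 2 both in the substituent and in where it sits on the phenyl ring, so the shown compounds cannot separate these two changes. A 2-chlorophenyl group, a 4-methoxyphenyl group or a plain phenyl group on the same nitrogen would show which change carries the loss.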